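Trading a methoxyphenyl for a chlorophenyl on the core

The source may report more compounds than this note shows. Statements on the series, on what has been measured and on what is new or still open speak of the compounds shown alone.

Of the compounds shown here, three have been tested in a functional assay on U-87MG ATCC cells for antiproliferative activity against U-87 MG (Homo sapiens), read by MTT assay, with a stated time of 48 h, tested at 10 uM; on this read-out higher numbers stand for a weaker effect at the one concentration tested and lower numbers for a stronger effect. Compound 1, `COc1ccc(-c2nc(SCC(=O)c3sc(-c4ccccc4)nc3C)[nH]c(=O)c2C#N)cc1`, gives 90.4%, the highest of the three numbers and therefore the weakest effect seen so far. For the measured compounds named here, compound 3, `COc1ccc(-c2nc(C)c(C(=O)CSc3nc(-c4ccc(OC)cc4)c(C#N)c(=O)[nH]3)s2)cc1`, gives 80.3%; the one step that connects it to compound 1, a number 10.1 percentage points lower from compound 1 to compound 3 (beyond the scatter), is modest but beyond the scatter. Going by the values given here, compound 2, `Cc1nc(-c2ccc(Cl)cc2)sc1C(=O)CSc1nc(N)c(C#N)c(-c2ccc(Cl)cc2)n1`, gives 37.3%, far below compound 1, but its structure differs from compound 1 in several places at once, so no single step can be drawn from it.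

Compound 4, `Cc1nc(-c2ccccc2)sc1C(=O)CSc1nc(-c2cccc(Cl)c2)c(C#N)c(=O)[nH]1`, has not yet been measured. It differs from compound 1 as follows: 3-chlorophenyl in place of 4-methoxyphenyl on an aromatic carbon. Among the compounds with values here, no measured step touches this place on the core; the only measured step, from compound 1 to compound 3, concerns a methoxy on the other ring. Compound 2 shows that compounds carrying chlorophenyl groups can give a low number, but its many differences prevent any firm reading. A modest move toward a stronger effect is therefore expected, though the scatter could swallow it.

For compound 4 the expected value in this assay is 78%, with a range from 55% to 97%, meaning an expected step of a number 12.4 percentage points lower from compound 1 to compound 4 (beyond the scatter).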

Compound 4, a percentage reported as activity, at one concentration (the size of the read-out at that concentration, not a potency): 83.7%
Beside the measured number, compound 4's estimate is 5.7 percentage points below it; low and high end bracket the measured number.
By their numbers in this assay, from the lowest: compound 2; then compounds 3, 4 and 1 (each within the scatter of the next, the first and the last beyond it).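

In this assay, putting 3-chlorophenyl in place of 4-methoxyphenyl on the aromatic carbon ortho to a cyano group gives a number 6.7 percentage points lower from compound 1 to compound 4 (within the scatter), so at this one concentration the change cannot be told apart from repeat-to-repeat variation. For the compounds shown here, this is the first measured step at this place on the shared core, and it shows only that this particular exchange leaves no clear mark on the read-out, even though the leaving and entering groups differ in both their substituent and where it sits on the phenyl ring. No separate measurement of any property of these groups bears on this result, so the data offer no explanation for it.

The step changes the substituent and its ring position together, so the compounds shown leave open what each contributes on its own. Also open, going by these compounds, is how this read-out would respond to a stronger change at this place, such as an amine or a carboxylic acid on the phenyl ring, or a longer chain in place of the ring.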